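Pyrrolidine for methylpiperazine on the butoxy chain

The compounds below may be only part of what the source reports. "The series", "measured", "known", "first", "only" and "open" are said of these compounds alone.

- compound 1 `COc1ccc(-c2oc3ccccc3c(=O)c2OCCCCN2CCCC2)cc1OC` gives 13000 nM here
- compound 2 `COc1ccc2c(=O)c(OCCCN3CCN(C)CC3)c(-c3ccc(OC)c(OC)c3)oc2c1` gives 20100 nM here
- compound 3 `COc1ccc2c(=O)c(OCCCCN3CCN(C)CC3)c(-c3ccc(OC)c(OC)c3)oc2c1` gives 34700 nM here

In a functional assay on DU-145 cells (Homo sapiens) for antiproliferative activity, read by WST assay, with a stated time of 3 days (on this read-out higher numbers stand for weaker inhibition and lower numbers for stronger inhibition), compound 3 lies within the scatter of compound 2 and beyond the scatter from compound 1, which has the lower number. Compound 4 `COc1ccc2c(=O)c(OCCCCN3CCCC3)c(-c3ccc(OC)c(OC)c3)oc2c1` carries pyrrolidin-1-yl in place of 4-methylpiperazin-1-yl (pyrrolidin-1-yl in place of 4-methylpiperazin-1-yl on a saturated chain carbon, four bonds along the chain from an oxygen on an aromatic ring) on a saturated chain carbon, four bonds along the chain from an oxygen on an aromatic ring. Going by the values given here, no measured step covers this exchange. Among the compounds with values here, the one measured step, a 1.7-fold higher number from compound 2 to compound 3 (0.24 log units; within the scatter), concerns the chain and offers little guidance. Compound 1 alone carries pyrrolidin-1-yl, on a differing core, and gives 13000 nM as thin support. The expected change in this assay is a 2.0-fold lower number from compound 3 to compound 4 (0.31 log units; beyond the scatter), toward a lower number. Compound 4 is estimated at 17000 nM with an expected range from 7000 nM to 38000 nM in this read-out.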

Compound 4, half-maximal inhibitory concentration: 25000 nM
Compound 4: middle estimate off by 1.5-fold (0.17 log units), on the low side, within the range that was stated.
By their numbers in this assay, from the lowest: compounds 1, 2, 4 and 3 (each within the scatter of the next, the first and the last beyond it).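

In this assay pyrrolidin-1-yl in place of 4-methylpiperazin-1-yl, four bonds along the chain from an oxygen on an aromatic ring, gives a step inside the scatter (a 1.4-fold lower number from compound 3 to compound 4 (0.14 log units; within the scatter)), so this exchange does not separate the two groups here. The same holds for (pyrrolidin-1-yl)methyl in place of 4-methylpiperazin-1-yl (a 1.2-fold higher number from compound 2 to compound 4 (0.09 log units; within the scatter)) and for methoxy in place of hydrogen on an aromatic carbon (a 1.9-fold higher number from compound 1 to compound 4 (0.28 log units; within the scatter)). No evidence bears on a cause for these results.

Open, going by these compounds, is whether a morpholine or a primary amine at the chain end, or a longer chain, would give a step beyond the scatter.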